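Swapping nitro for methoxycarbonyl on the shared core

The source may hold more compounds than are shown below. What is called first, only, known or untested is meant among the compounds shown, and "the series" means these compounds.

Compound 1 `CCc1ccc(N2C(=O)C=CC2OCC(F)(F)F)cc1`: 6510 nM
Compound 2 `O=C1C=CC(OCC(F)(F)F)N1c1ccc([N+](=O)[O-])cc1`: 2380 nM

In a functional assay on HeLa cells (Homo sapiens) for inhibition (on this read-out higher numbers stand for weaker inhibition and lower numbers for stronger inhibition), compound 2 holds the lower of the two numbers measured. Among the measured compounds shown here, the only measured step is a 2.7-fold lower number from compound 1 to compound 2 (0.44 log units; beyond the scatter). Compound 3 `COC(=O)c1ccc(N2C(=O)C=CC2OCC(F)(F)F)cc1` differs from compound 2 by methoxycarbonyl in place of nitro on an aromatic carbon. For the measured compounds named here, no measured step exchanges nitro for methoxycarbonyl, and the ethyl-to-nitro step, though modest, does not bear directly on this change. No change beyond the scatter is therefore expected in this assay. Compound 3 is estimated at 3000 nM, within 1200 nM to 8000 nM. This estimate corresponds to a 1.3-fold higher number from compound 2 to compound 3 (0.10 log units; within the scatter).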

Compound 3, half-maximal inhibitory concentration: 5700 nM
Beside the measured number, compound 3's estimate is 1.9-fold (0.28 log units) below it, within the range that was stated.
By their numbers in this assay, from the lowest: compound 2; then compounds 3 and 1 (each within the scatter of the next).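

In this assay, the step for methoxycarbonyl in place of nitro on this aromatic carbon is a 2.4-fold higher number from compound 2 to compound 3 (0.38 log units; beyond the scatter), although the two groups have equal counts of hydrogen-bond donors and acceptors. Methoxycarbonyl in place of ethyl gives a 1.1-fold lower number from compound 1 to compound 3 (0.06 log units; within the scatter), so among these three groups only nitro stands apart. Nothing available explains this difference. From the compounds shown here alone, whether an amine, a carboxylic acid or a nitrile at this position would track nitro or the other two groups remains open. So does whether nitro keeps its edge against such groups.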